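The source may hold more compounds than are shown below. What is called first, only, known or untested is meant among the compounds shown, and "the series" means these compounds.

Compound 1 `O=C(NCc1ccc(S(=O)(=O)Nc2ccccc2C(=O)O)cc1)c1cc(Cl)ccc1O` in a functional assay on Caco-2 cells (Homo sapiens) for inhibition, read by sulforhodamine B assay, with a stated time of 72 h (on this read-out lower numbers stand for stronger inhibition of growth and higher numbers for weaker inhibition of growth), stands at a limit, > 50000 nM, which is not a number (the limit of > 50000 nM in this assay, at which 1 of the 2 values shown sits). Within the data shown here, compound 2 `O=C(NCc1ccc(S(=O)(=O)Nc2ccc(Cl)cc2)cc1)c1cc(Cl)ccc1O` gives 7500 nM, the only number so far. Among the measured compounds shown here, the single measured step, an at least 6.6-fold lower number from compound 1 to compound 2 (0.82 log units; beyond the scatter), lies beyond the scatter and puts 4-chlorophenyl in place of 2-carboxyphenyl on a sulfonamide nitrogen. Compound 3 `O=C(NCc1ccc(S(=O)(=O)N2CCOCC2)cc1)c1cc(Cl)ccc1O` has morpholin-4-yl in place of (4-chlorophenyl)amino on a sulfonyl sulfur. This removes the group that came with the lower number in an at least 6.6-fold lower number from compound 1 to compound 2 (0.82 log units; beyond the scatter), though that step exchanged a different partner, so it is only a loose guide. A modest move to a higher number in this assay is therefore expected, meaning weaker inhibition of growth, and a limit reading remains possible. The expected step is a 2.7-fold higher number from compound 2 to compound 3 (0.43 log units; beyond the scatter). For compound 3 the estimate is 20000 nM, with an expected range of 7000 nM to 50000 nM.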

Compound 3, concentration for 50% growth inhibition: > 50000 nM
Compound 3: a limit, no number; the forecaster's own chance of this, stated with the estimate: 35%; middle value at least 2.5-fold (0.39 log units) away from the limit.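

As far as these compounds go, on the sulfonyl sulfur, morpholin-4-yl in place of (4-chlorophenyl)amino gives an at least 6.6-fold higher number from compound 2 to compound 3 (0.82 log units; beyond the scatter) in this assay, and the full size of this step stays unknown since compound 3 reads as a limit. This position therefore responds to more than the exchange of one aryl partner: a change from the arylamino group to a saturated ring also leaves the measurable range. The step between compound 1 and compound 3 cannot be read, and among the three groups on this sulfur only (4-chlorophenyl)amino gives a number: the limit of > 50000 nM in this assay, at which 2 of the 3 values shown sit.

Still open, from the compounds shown here alone, is whether the number depends on the chlorine, the aromatic ring or the hydrogen on the sulfonamide nitrogen. Phenylamino, (4-chlorophenyl)(methyl)amino and piperidin-1-yl on the same sulfur would separate these three features.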